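Piperazine in place of piperidine on the side chain

The source may report more compounds than this note shows. Statements on the series, on what has been measured and on what is new or still open speak of the compounds shown alone.

The measured compounds:
compound 1 `COc1cc2c(Oc3ccc(NC(=O)c4cn(-c5ccccc5)nn4)cc3F)ccnc2cc1OCCCN1CCCC1`, 260 nM
compound 2 `COc1cc2c(Oc3ccc(NC(=O)c4cn(-c5ccccc5)nn4)cc3F)ccnc2cc1OCCCN1CCCCC1`, 100 nM
compound 3 `COc1cc2c(Oc3ccc(NC(=O)c4cn(-c5c(C)cccc5C)nn4)cc3F)ccnc2cc1OCCCN1CCCCC1`, 2140 nM

In a functional assay on MKN-45 cells (Homo sapiens) for cytotoxicity, read by MTT assay, with a stated time of 72 h (on this read-out lower numbers stand for stronger inhibition and higher numbers for weaker inhibition), compound 2 gives the lowest number of the three. The step from its nearest neighbour is a 2.6-fold lower number from compound 1 to compound 2 (0.41 log units; beyond the scatter), and the step to the furthest is a 21-fold higher number from compound 2 to compound 3 (1.33 log units; beyond the scatter). Compound 4 `COc1cc2c(Oc3ccc(NC(=O)c4cn(-c5ccccc5)nn4)cc3F)ccnc2cc1OCCCN1CCN(C)CC1` has not been measured. It differs from compound 2 in one place: 4-methylpiperazin-1-yl in place of piperidin-1-yl on a saturated chain carbon, three bonds along the chain from an oxygen on an aromatic ring.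

Going by the values given here, only one measured step touches the same place on the chain, a 2.6-fold lower number from compound 1 to compound 2 (0.41 log units; beyond the scatter), and it swapped the size of the ring rather than its hetero atom count, so it bears on the present change only loosely. The step of a 21-fold higher number from compound 2 to compound 3 (1.33 log units; beyond the scatter) concerns the other end of the molecule and says nothing about this position. Among the compounds with values here, with no close precedent, a change of a nitrogen-bearing ring at this distance from the aromatic oxygen is expected to move the number only modestly in this assay, and in an uncertain direction, most likely within or just beyond the scatter. For compound 4 the expected step is a 1.5-fold higher number from compound 2 to compound 4 (0.18 log units; within the scatter). Compound 4 is therefore estimated at 150 nM, between 50 nM and 500 nM.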

Compound 4, half-maximal inhibitory concentration: 60 nM
Beside the measured number, compound 4's estimate is 2.5-fold (0.40 log units) above it; the range from low to high includes it.
By their numbers in this assay, from the lowest: compounds 4 and 2 (each within the scatter of the next); then compound 1; then compound 3.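

In this assay this place on the chain accepts 4-methylpiperazin-1-yl as readily as piperidin-1-yl: a 1.7-fold lower number from compound 2 to compound 4 (0.22 log units; within the scatter), so the extra ring nitrogen and its methyl group leave compound 4 indistinguishable from compound 2. The other new step, a 4.3-fold lower number from compound 1 to compound 4 (0.64 log units; beyond the scatter), separates 4-methylpiperazin-1-yl from pyrrolidin-1-yl, so with phenyl kept on the aromatic nitrogen, both six-membered rings give lower numbers than pyrrolidin-1-yl. Nothing in the available data accounts for these numbers.

The compounds shown leave open whether morpholin-4-yl, an unsubstituted piperazin-1-yl or a longer chain between the aromatic oxygen and the ring would behave in the same way. They also leave open whether 2,6-dimethylphenyl on the aromatic nitrogen would raise the number as sharply with 4-methylpiperazin-1-yl on the chain.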